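Anilide series: removing the chlorobenzoyl group from compound 1

The compounds below may be only part of what the source reports. "The series", "measured", "known", "first", "only" and "open" are said of these compounds alone.

Measured compounds in a functional assay on NUGC-3 cells (Homo sapiens) for inhibition, read by sulforhodamine B assay, with a stated time of 48 h; on this read-out lower numbers stand for stronger inhibition of growth and higher numbers for weaker inhibition of growth:
- compound 1, `COc1ccc(NC(=O)C2c3ccccc3CCN2C(=O)c2ccc(Cl)cc2)cc1`: compound 1 gives 3630 nM.
- compound 2, `O=C(Nc1cccc(O)c1)C1c2ccccc2CCN1C(=O)c1ccc(Cl)cc1`: compound 2 gives > 10000 nM, a limit of the assay.
- compound 3, `O=C(Nc1ccccc1O)C1c2ccccc2CCN1C(=O)c1ccc(Cl)cc1`: compound 3 gives > 10000 nM, a limit of the assay.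

Compound 1 holds the only number shown in this assay; the other two values are limits, as the limit of > 10000 nM in this assay, at which 2 of the 3 values shown sit, records. The measured steps concern only the anilide aryl: an at least 2.7-fold higher number from compound 1 to compound 2 (0.44 log units; beyond the scatter) and an at least 2.7-fold higher number from compound 1 to compound 3 (0.44 log units; beyond the scatter), while a step that the two limits leave unreadable from compound 2 to compound 3.

Compound 4, `COc1ccc(NC(=O)C2NCCc3ccccc32)cc1`, differs from compound 1 at a different place: hydrogen in place of (4-chlorophenyl)carbonyl on an amine nitrogen in a ring. For the measured compounds named here, no measured step changes this part of the shared core, so the earlier steps give no direct reading of its size or direction. Going by the values given here, the only anchor is compound 1 with its 3630 nM, and the change removes a large part of that structure. Compound 4 is therefore expected to show weaker growth inhibition in this assay, with a fair chance that only a limit is reported. The expected step is a 3.3-fold higher number from compound 1 to compound 4 (0.52 log units; beyond the scatter). The estimate for compound 4 is 12000 nM, within a range from 2500 nM to 50000 nM.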

Compound 4, concentration for 50% growth inhibition: > 10000 nM
Compound 4 ended at the assay's limit; the forecaster's own chance of this, stated with the estimate: 55%; the middle value does not contradict the limit.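

Hydrogen in place of (4-chlorophenyl)carbonyl on the amine nitrogen in a ring gives, in this assay, an at least 2.7-fold higher number from compound 1 to compound 4 (0.44 log units; beyond the scatter), the first reading at this position, as all earlier steps concerned the anilide aryl. Compound 4 gives > 10000 nM, which is a limit of the assay and not a number, so this step fixes a direction and a minimum size only. Compound 1 remains the only compound with a number, and the series now gathers at one ceiling: the limit of > 10000 nM in this assay, at which 3 of the 4 values shown sit.

The compounds shown leave open which part of the (4-chlorophenyl)carbonyl group matters, the chlorine, the aromatic ring or the carbonyl. An acetyl, an unsubstituted benzoyl or a 4-chlorobenzyl group on this nitrogen would separate these parts.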